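Methoxy to hydroxy on the saturated ring carbon

The source may report more compounds than this note shows. Statements on the series, on what has been measured and on what is new or still open speak of the compounds shown alone.

Measured so far:
compound 1, `c1ccc(CN2CCC3(CC2)OCCc2ccsc23)cc1`, 1 nM
compound 2, `COC1Cc2ccsc2C2(CCN(Cc3ccccc3)CC2)O1`, 1.9 nM

In an assay on membranes from brain for displacement of a labelled ligand from Sigma non-opioid intracellular receptor 1 (Cavia porcellus), read by scintillation counting, with a stated time of 120 min (on this read-out higher numbers stand for weaker inhibition and lower numbers for stronger inhibition), compound 2 shows the higher of the two numbers; its nearest neighbour is compound 1, with a 1.9-fold higher number from compound 1 to compound 2 (0.28 log units; within the scatter). Compound 3, `OC1Cc2ccsc2C2(CCN(Cc3ccccc3)CC2)O1`, differs from compound 2 by hydrogen in place of methyl on an oxygen on a saturated carbon. Among the measured compounds shown here, only one measured step touches this carbon, a 1.9-fold higher number from compound 1 to compound 2 (0.28 log units; within the scatter), and it concerns the methoxy entering, not the methyl leaving the oxygen; no measured step covers a methoxy-to-hydroxy change. Since that single step stayed within the scatter, the estimated step here is a 1.3-fold higher number from compound 2 to compound 3 (0.12 log units; within the scatter), no direction beyond the scatter. Compound 3 is therefore expected at 2.5 nM, within 0.8 nM to 8 nM.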

Compound 3, inhibition constant: 16 nM
Compound 3: middle estimate off by 6.4-fold (0.81 log units), on the low side; the whole stated range lies below it.
By their numbers in this assay, from the lowest: compounds 1 and 2 (each within the scatter of the next); then compound 3.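

In this assay, the methyl on the oxygen at this saturated ring carbon proves to matter: its loss gives an 8.4-fold higher number from compound 2 to compound 3 (0.93 log units; beyond the scatter), whereas the methoxy entering had given a 1.9-fold higher number from compound 1 to compound 2 (0.28 log units; within the scatter). Hydroxy in place of hydrogen on the same carbon gives a 16-fold higher number from compound 1 to compound 3 (1.20 log units; beyond the scatter), so this carbon does not treat every oxygen substituent alike. No available evidence accounts for the difference between methoxy and hydroxy here.

As far as these compounds go, whether a longer chain on the oxygen, such as ethoxy, stays close to compound 2 remains open. So does the outcome with an amine on this carbon.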